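The compounds below may be only part of what the source reports. "The series", "measured", "known", "first", "only" and "open" are said of these compounds alone.

Measured so far:
compound 1 `C[C@@H]1CN(c2cccc3ccccc23)CCN1CN1CC(=O)N2CCC[C@H]2C1=O` — an assay on membranes from Cerebral cortex for binding affinity to Adrenergic receptor alpha-1 (Rattus norvegicus); a lower number here means a stronger inhibitor, a higher number a weaker inhibitor: > 1000 nM
compound 2 `O=C1C2CCCN2C(=O)CN1CCCCN1CCN(c2cccc3c2COC=CO3)CC1` — this assay: > 1000 nM

The value of compound 1 is a limit of the assay, not a number. The value of compound 2 is also a limit. This places compound 1 at the limit of > 1000 nM in this assay, at which 2 of the 2 values shown sit. Compound 3 `C[C@H]1CN(c2cccc3ccccc23)CCN1CN1CC(=O)N2CCC[C@H]2C1=O` is not yet measured; compared with compound 1, (the two compounds have the same atoms and bonds and differ only in configuration as drawn: 1 of 2 stereo elements differ; a stereocentre at a saturated ring carbon is drawn R in compound 1 and S in compound 3). Going by the values given here, no measured pair here differs in this way, so there is no ground to expect a step beyond the scatter in this assay. Compound 3 is expected at about 1500 nM, between 600 nM and 5000 nM. The expected step is a step that the limit leaves unreadable from compound 1 to compound 3.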

Compound 3, inhibition constant: > 1000 nM
Compound 3: a limit, no number; the forecaster's own chance of this, stated with the estimate: 70%; the middle value lies beyond the limit too.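

No step from compound 1 to compound 3 can be read, because both values are limits of the assay, not numbers: the limit of > 1000 nM in this assay, at which 3 of the 3 values shown sit.

The compounds shown leave open whether changing the saturated ring carbon from R to S alters binding affinity at all, since none of them gives a number.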